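Swapping the Aryl Group: From Neopentyloxy to Oxazolyl

A few compounds are considered here, and "the series" means these few. Any claim that something is new, unique, unknown or untested is made for them only; others in the source may bear on it.

Of the compounds shown here, two built on one shared core have so far been tested in a functional assay on aorta for antagonist activity at Alpha-1D adrenergic receptor (Rattus norvegicus); on this read-out higher numbers stand for weaker binding and lower numbers for tighter binding. Compound 1 `CN(C)C(=O)c1cccnc1NCCCN1CCN(c2ccccc2C#N)CC1` carries a cyano group on its carbon-only aromatic ring and gives 10 nM. Compound 2 `CN(C)C(=O)c1cccnc1NCCCN1CCN(c2ccccc2OCC(C)(C)C)CC1` carries a neopentyloxy group at that same position and gives 50.1 nM; the step of a 5.0-fold higher number from compound 1 to compound 2 (0.70 log units; beyond the scatter) is a clear shift. Going by the values given here, compound 2 therefore stands at the higher of the two numbers, with compound 1 as its only neighbour.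

Compound 3 `CN(C)C(=O)c1cccnc1NCCCN1CCN(c2ccccc2-c2ncco2)CC1` has not yet been measured. It differs from compound 2 by 1,3-oxazol-2-yl in place of neopentyloxy on an aromatic carbon. Among the compounds with values here, the only measured step that bears on this position is the one from compound 1 to compound 2, which showed that an exchange here can move the number beyond the scatter. With compound 1 at 10 nM and compound 2 at 50.1 nM as the bracketing references, compound 3 is expected to fall between them, an expected step of a 2.5-fold lower number from compound 2 to compound 3 (0.40 log units; beyond the scatter). The estimate for compound 3 is 20 nM, with a range from 6 nM to 63 nM.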

Compound 3, dissociation constant: 25.1 nM
Beside the measured number, compound 3's estimate is 1.3-fold (0.10 log units) below it, and the stated range covers the measured number.
By their numbers in this assay, from the lowest: compound 1; then compounds 3 and 2 (each within the scatter of the next).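

In this assay, putting 1,3-oxazol-2-yl, which carries a five-membered aromatic ring, in place of neopentyloxy, which has no ring, gives a step that stays within the usual scatter (a 2.0-fold lower number from compound 2 to compound 3 (0.30 log units; within the scatter)), so this read-out does not separate these two quite different groups. The same position is still not indifferent to what sits there: the exchange of cyano for 1,3-oxazol-2-yl lies beyond the scatter (a 2.5-fold higher number from compound 1 to compound 3 (0.40 log units; beyond the scatter)), which leaves compound 1 clearly apart from both other compounds, with the lowest number and so the tightest binding of the three. No supporting measurement is available to explain why cyano stands apart or why the other two groups cannot be told apart.

The compounds shown leave open whether any group at this position can reach a lower number than cyano, for example a methoxy group, a chlorine atom, an amine or a carboxylic acid. They also leave open whether the same order of these three groups would hold if another part of the shared core were changed.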